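Swapping Ethoxyphenyl for 3-Amino-4-methoxyphenyl

A few compounds are considered here, and "the series" means these few. Any claim that something is new, unique, unknown or untested is made for them only; others in the source may bear on it.

Of the compounds shown here, three sharing one core have been measured in a functional assay on A2780 cells (Homo sapiens) for antiproliferative activity, read by MTT assay, with a stated time of 48 h; on this read-out higher numbers stand for weaker inhibition and lower numbers for stronger inhibition. There, compound 1 `COc1ccc(-c2cc3c(cn2)[nH]c(=O)n3-c2cc(OC)c(OC)c(OC)c2)cc1` gives 930 nM, compound 2 `COc1ccc(-c2cc3c(cn2)[nH]c(=O)n3-c2cc(OC)c(OC)c(OC)c2)cc1F` gives 730 nM, and compound 3 `CCOc1ccc(-c2cc3c(cn2)[nH]c(=O)n3-c2cc(OC)c(OC)c(OC)c2)cc1` gives 2980 nM. Compound 3 therefore has the highest number of the three and the weakest inhibition in this small set.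

The next compound, compound 4 `COc1ccc(-c2cc3c(cn2)[nH]c(=O)n3-c2cc(OC)c(OC)c(OC)c2)cc1N`, has 3-amino-4-methoxyphenyl in place of 4-ethoxyphenyl on an aromatic carbon, next to the ring nitrogen: 3-amino-4-methoxyphenyl in place of 4-ethoxyphenyl on an aromatic carbon.

Going by the values given here, three measured steps bear on this change. Methyl in place of hydrogen on the chain carbon bound to oxygen gave a 3.2-fold higher number from compound 1 to compound 3 (0.51 log units; beyond the scatter), and 4-ethoxyphenyl in place of 3-fluoro-4-methoxyphenyl gave a 4.1-fold higher number from compound 2 to compound 3 (0.61 log units; beyond the scatter). Fluoro in place of hydrogen on the aromatic carbon gave a 1.3-fold lower number from compound 1 to compound 2 (0.11 log units; within the scatter), so that added group left the number of compound 2 within the scatter of compound 1. Among the compounds with values here, no measured compound carries an amino group, which leaves that part of the forecast uncertain.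

Compound 4 keeps the methoxy group found in compound 1 and compound 2, so it is expected to sit nearer to them than to compound 3. In this assay, the expected change is a 5.0-fold lower number from compound 3 to compound 4 (0.70 log units; beyond the scatter), a modest move toward stronger inhibition. Compound 4 is estimated at 600 nM, with an expected range from 150 nM to 2000 nM.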

Compound 4, half-maximal inhibitory concentration: 640 nM
Compound 4: the middle estimate sits 1.1-fold (0.03 log units) below what was measured; measured number inside the range.
By their numbers in this assay, from the lowest: compounds 4, 2 and 1 (each within the scatter of the next); then compound 3.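

In this assay, the exchange at this aromatic carbon gave a 4.7-fold lower number from compound 3 to compound 4 (0.67 log units; beyond the scatter), the first step shown that brings in an amino group, and it carried the number back into the range of the methoxy compounds. Amino in place of fluoro gave a 1.1-fold lower number from compound 2 to compound 4 (0.06 log units; within the scatter) and amino in place of hydrogen gave a 1.5-fold lower number from compound 1 to compound 4 (0.16 log units; within the scatter), so with the methoxy group kept, hydrogen, fluoro and amino on the phenyl ring are not told apart by this read-out, while the ethoxy compound, compound 3, remains the only one set apart from the others. No measurement is available to explain why the amino group leaves the number unmoved or why the ethoxy compound stands apart.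

The compounds shown leave open whether a larger nitrogen group in the same place, such as dimethylamino or acetamido, or a hydroxyl group, would also keep the number within this range. They also leave open whether an amino group could restore the number when paired with ethoxy rather than methoxy, since every compound carrying an added group on the phenyl ring here has the methoxy group.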